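One Group Moved: From Compound 3 to Compound 4

The source may hold more compounds than are shown below. What is called first, only, known or untested is meant among the compounds shown, and "the series" means these compounds.

Of the compounds shown here, three have so far been tested in an ADME assay on HFF cells (Homo sapiens) for cytotoxicity, read by MTT assay, with a stated time of 72 h; a higher number here means a weaker inhibitor, a lower number a stronger inhibitor. Compound 1, `O=C1O/C(=C\Cn2cc(-c3ccc(Br)cc3)nn2)C(OCc2ccccc2)=C1OCc1ccccc1`, gives > 100000 nM, which is a limit of the assay rather than a measured number. Compound 2, `CCCCCc1ccc(-c2cn(C/C=C3\OC(=O)C(OCc4ccccc4)=C3OCc3ccccc3)nn2)cc1`, gives > 100000 nM, again only a limit. Going by the values given here, compound 3, `COc1ccccc1-c1cn(C[C@H](O)[C@H]2OC(=O)C(OCc3ccccc3)=C2OCc2ccccc2)nn1`, gives 50 nM in this assay, and this is the only true number among the three values. The other two sit at the limit of > 100000 nM in this assay, at which 2 of the 3 values shown sit. The step that the two limits leave unreadable from compound 1 to compound 2 cannot be read because both of its ends are limits, so it tells nothing about how big a change in this assay a change of group can bring.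

Compound 4, `COc1ccc(-c2cn(C[C@H](O)[C@H]3OC(=O)C(OCc4ccccc4)=C3OCc3ccccc3)nn2)cc1`, differs from compound 3 in a single place: 4-methoxyphenyl in place of 2-methoxyphenyl on an aromatic carbon. Among the compounds with values here, none of the measured steps bears on this change, and the one readable number offers no comparison. The expectation therefore rests on compound 3 alone. Compound 4 is expected to land near compound 3, with a step of a 2.0-fold higher number from compound 3 to compound 4 (0.30 log units; within the scatter) and no direction favoured beyond the usual scatter. The estimate for compound 4 in this assay is 100 nM, with a range from 15 nM to 1500 nM.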

Compound 4, half-maximal inhibitory concentration: < 10 nM
Compound 4 gave a limit, no number; the forecaster's own chance of this, stated with the estimate: 10%; middle value at least 10-fold (1.00 log units) away from the limit.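

Replacing 2-methoxyphenyl with 4-methoxyphenyl on the aromatic carbon of the five-membered ring gives an at least 5.0-fold lower number from compound 3 to compound 4 (0.69 log units; beyond the scatter) in this assay. The two groups have the same atoms and the same counts of hydrogen-bond donors and acceptors, so this pair shows that the read-out can respond to where the methoxy sits on the phenyl ring, even when the group's composition stays the same. Going by these compounds alone, the only earlier step cannot be read, which makes this the first change with a readable size, though compound 4 gives < 10 nM, a limit of the assay and not a number, so the step has a known minimum but no known full size.

The compounds shown leave open how large the step really is and whether the change in position would matter in the same way for other groups. An amine or a carboxylic acid in place of the methoxy at the 4-position of the phenyl ring, or a longer chain such as ethoxy, would test whether the result is specific to methoxy.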